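The compounds below may be only part of what the source reports. "The series", "measured", "known", "first", "only" and "open" are said of these compounds alone.

Measured so far in an assay on isolated protein for binding affinity to corticotropin-releasing factor receptor 1 (Homo sapiens); on this read-out higher numbers stand for weaker inhibition and lower numbers for stronger inhibition:
Compound 1 `CCCN(CCC)c1cc(C)nc2c(-c3ncc([N+](=O)[O-])cc3C)c(C)nn12` gives 9.1 nM in this assay.
Compound 2 `CCCN(CCC)c1cc(C)nc2c(-c3ncc(C)cc3[N+](=O)[O-])c(C)nn12` gives 14 nM in this assay.
Compound 3 `CCCN(CCC)c1cc(C)nc2c(-c3ncc(NC)cc3C)c(C)nn12` gives 40 nM in this assay.

Compound 3 stands highest of the three, beyond the scatter from both others, so it is the weakest binder measured here. Compound 4 `CCCN(CCC)c1cc(C)nc2c(-c3ncc(N=O)cc3C)c(C)nn12` differs from compound 3 in one place: a group of 2 heavy atoms (1 nitrogen, 1 oxygen; no ring) in place of a group of 2 heavy atoms (1 carbon, 1 nitrogen; no ring), on an aromatic carbon. Among the compounds with values here, one measured step bears on this change, a 4.4-fold higher number from compound 1 to compound 3 (0.64 log units; beyond the scatter), in which methylamino replaced nitro and weakened binding. The group entering compound 4 resembles that nitro more closely than it resembles methylamino, so a partial reversal of that step is expected, with the number falling: a 2.7-fold lower number from compound 3 to compound 4 (0.43 log units; beyond the scatter). The estimate for compound 4 in this assay is therefore 15 nM, expected to lie between 6 nM and 40 nM.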

Compound 4, inhibition constant: 100 nM
For compound 4 the middle estimate is 6.7-fold (0.82 log units) below the measured one; the measured number lies above the stated range.
By their numbers in this assay, from the lowest: compounds 1 and 2 (each within the scatter of the next); then compound 3; then compound 4.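

In this assay, the group entering compound 4 does not act as a smaller stand-in for nitro at this aromatic carbon, since binding weakens by an 11-fold higher number from compound 1 to compound 4 (1.04 log units; beyond the scatter) and this large loss sets it well apart from nitro. Sharing nitrogen and oxygen with nitro therefore did not preserve binding here. It also falls behind methylamino, with a 2.5-fold higher number from compound 3 to compound 4 (0.40 log units; beyond the scatter) as the step, so the earlier step did not predict this change, and nothing shown explains the loss. On these data alone, whether a plain amine or a nitrile at this carbon would match nitro stays open.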